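The compounds below may be only part of what the source reports. "The series", "measured", "known", "first", "only" and "open" are said of these compounds alone.

Three compounds from one series share a core that differs only in the group attached to an amide carbonyl and, in one case, in a methyl group on the core. Compound 1 `C=C(Cl)C(=O)Nc1cc(Nc2nccc(-c3cn(C)c4ccccc34)n2)c(OC)cc1N(C)CCN(C)C` carries a 1-chloroethenyl group there, compound 2 `CCC/C=C\C(=O)Nc1cc(Nc2nccc(-c3cn(C)c4ccccc34)n2)c(OC)cc1N(C)CCN(C)C` a pent-1-en-1-yl group, and compound 3 `C=CC(=O)Nc1cc(Nc2nc(C)cc(-c3cn(C)c4ccccc34)n2)c(OC)cc1N(C)CCN(C)C` a plain vinyl group on the methyl-bearing core. In a functional assay on A549 cells (Homo sapiens) for antiproliferative activity, read by MTT assay, with a stated time of 72 h (a higher number here means a weaker inhibitor, a lower number a stronger inhibitor), compound 1 gives 7520 nM, compound 2 gives 808 nM and compound 3 gives 2910 nM. Compound 3 thus stands second highest of the three numbers, closer to compound 1 than to compound 2.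

Compound 4 `CC/C=C\C(=O)Nc1cc(Nc2nc(C)cc(-c3cn(C)c4ccccc34)n2)c(OC)cc1N(C)CCN(C)C` is the not yet measured partner of compound 3. The change is but-1-en-1-yl in place of vinyl on a carbonyl carbon. For the measured compounds named here, only one measured step bears on this kind of change: a 9.3-fold lower number from compound 1 to compound 2 (0.97 log units; beyond the scatter), where a longer alkenyl chain on the same carbonyl carbon went with a clearly lower number. Compound 4 repeats a similar lengthening on the methyl-bearing core, so a step in the same direction, beyond the scatter but likely smaller than that one, is expected.

For compound 4 the expected value in this assay is 1000 nM, within a range of 400 nM to 3000 nM, which corresponds to an expected step of a 2.9-fold lower number from compound 3 to compound 4 (0.46 log units; beyond the scatter).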

Compound 4, half-maximal inhibitory concentration: 1090 nM
Estimate against measurement, compound 4: 1.1-fold (0.04 log units) below, and the stated range covers the measured number.
By their numbers in this assay, from the lowest: compounds 2 and 4 (each within the scatter of the next); then compound 3; then compound 1.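

In this assay, lengthening the group on the carbonyl carbon gives a 2.7-fold lower number from compound 3 to compound 4 (0.43 log units; beyond the scatter), so a longer alkenyl chain also goes with a lower number when the starting group is plain vinyl, which carries no chlorine, and when the core bears the methyl group. The earlier step, a 9.3-fold lower number from compound 1 to compound 2 (0.97 log units; beyond the scatter), began from 1-chloroethenyl on the core without that methyl, so it could not separate the effect of adding chain carbons from that of losing the chlorine; here, the vinyl and but-1-en-1-yl groups differ only in chain length, and the two steps agree in direction but are not the same change, so their sizes cannot be set against each other. No measurement offered here explains why the longer chain goes with a lower number.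

The compounds shown leave open whether the number keeps falling with a longer chain on this core, as with pent-1-en-1-yl or hex-1-en-1-yl, or levels off. They also leave open whether the double bond matters, which a saturated butyl chain could test, and how a chain ending in an amine would compare.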